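A few compounds are considered here, and "the series" means these few. Any claim that something is new, unique, unknown or untested is made for them only; others in the source may bear on it.

Measured compounds:
Compound 1 `C=C1C(=O)OC[C@H]1CCOC(=O)Nc1cccc(Br)c1` — 590 nM
Compound 2 `C=C1C(=O)OC[C@@H]1CCOC(=O)Nc1ccccc1` — 780 nM

In a functional assay on RAW264.7 cells (Mus musculus) for inhibition, with a stated time of 30 min (a lower number here means a stronger inhibitor, a higher number a weaker inhibitor), compound 1 gives 590 nM. In this assay compound 2 gives 780 nM. Compound 2 thus carries the higher of the two numbers, but the gap to compound 1 is within the scatter, so the two cannot be told apart on these measurements.

Compound 3 `C=C1C(=O)OC[C@@H]1CCOC(=O)Nc1cccc(Br)c1` has not yet been measured in this assay. It differs from compound 2 in one place: bromo in place of hydrogen on an aromatic carbon. Within the data shown here, no step between measured compounds isolates this change, so its effect cannot be read from the data. Among the measured compounds shown here, with only two measured compounds whose numbers sit within the scatter of each other, no step beyond the scatter is expected in either direction. For compound 3 the estimated value in this assay is 620 nM, with a range of 300 nM to 1300 nM. This estimate corresponds to a step of a 1.3-fold lower number from compound 2 to compound 3 (0.10 log units; within the scatter), which is expected to fall within the scatter.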

Compound 3, half-maximal inhibitory concentration: 840 nM
Compound 3: the middle estimate sits 1.4-fold (0.13 log units) below what was measured; the measured number falls inside the stated range.
By their numbers in this assay, from the lowest: compounds 1, 2 and 3 (each within the scatter of the next).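

In this assay, bromo in place of hydrogen on an aromatic carbon gives a 1.1-fold higher number from compound 2 to compound 3 (0.03 log units; within the scatter) and so has no readable effect at this place when the stereocentre is drawn R. The drawn configuration at the saturated ring carbon can now be read on its own, with bromo held in place: going from S to R gives a 1.4-fold higher number from compound 1 to compound 3 (0.15 log units; within the scatter) and so does not separate the two forms in this assay. This comparison speaks to the stereocentre alone: the fact that compounds 1 and 3 differ only in the configuration as drawn.

The compounds shown leave open whether an amine, a carboxylic acid or a methoxy group on that aromatic carbon would give a step beyond the scatter. They also leave open whether the configuration can be read in the same way when hydrogen stands in place of bromo.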